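This account rests on a few compounds, and the source may have more. Where it says the series, first, only, none or still open, it means among the compounds named here.

Measured so far:
- compound 1, `CCC(CC)C(/C=C1\OC(=O)NC1=O)c1ccc(-c2ccc3cccc(F)c3c2)[nH]c1=O`, in an assay on membranes from Chem-1 cells for displacement of a labelled ligand from prostaglandin E2 receptor EP3 subtype (Homo sapiens), read by scintillation counting, with a stated time of 2 h; a higher number here means a weaker inhibitor, a lower number a stronger inhibitor: 13 nM
- compound 2, `CC(C)C(c1ccc(-c2ccc3cccc(F)c3c2)[nH]c1=O)C1SC(=O)NC1=O`, in this assay: 25 nM
- compound 3, `CC(C)[C@@H](c1ccc(-c2ccc3cccc(F)c3c2)[nH]c1=O)[C@H]1OC(=O)NC1=O`, in this assay: 27 nM

All three compounds share the same core, and each carries a small five-membered ring linked to a chain carbon that also bears a branched alkyl group. Compound 1 gives the lowest of the three numbers in this assay, but its gap to compound 2 is within the usual scatter of repeated measurements, so the two cannot be told apart; only the gap to compound 3 lies beyond that scatter.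

The next compound, compound 4, `O=C1NC(=O)/C(=C/C(Cc2ccccc2)c2ccc(-c3ccc4cccc(F)c4c3)[nH]c2=O)O1`, keeps the core and the ring of compound 1 and changes only the alkyl group: benzyl in place of pentan-3-yl on a saturated chain carbon bound to an aromatic carbon and a double-bonded chain carbon. For the measured compounds named here, no measured pair shows what this exchange does, so the expectation rests on compound 1 alone. A larger, ring-bearing group in that position could go either way, and the step from compound 1 to compound 4 in this assay is expected to be a 1.9-fold higher number from compound 1 to compound 4 (0.28 log units; within the scatter), which is roughly the size of the scatter itself and in the direction of a somewhat weaker inhibitor. Compound 4 is therefore estimated at 25 nM, with a plausible range from 8 nM to 80 nM.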

Compound 4, inhibition constant in the prostaglandin E2 receptor EP3 subtype assay: 33 nM
Beside the measured number, compound 4's estimate is 1.3-fold (0.12 log units) below it; low and high end bracket the measured number.
By their numbers in the prostaglandin E2 receptor EP3 subtype assay, from the lowest: compounds 1, 2, 3 and 4 (each within the scatter of the next, the first and the last beyond it).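

For the compounds shown here, exchanging a ring-free group for one with an aromatic ring at this position gives, in the prostaglandin E2 receptor EP3 subtype assay, a 2.5-fold higher number from compound 1 to compound 4 (0.40 log units; beyond the scatter), and this is the first step here that changes only one place. Going by these compounds alone, earlier comparisons among compounds 1, 2 and 3 could not show this, as those compounds differ in more than one place. The position therefore accepts benzyl in place of pentan-3-yl with only a modest loss, but in a physicochemical assay for solubility, in phosphate buffer, measured as kinetic solubility (a lower number here means a less soluble compound, a higher number a more soluble compound), the same exchange also leaves a less soluble compound: the measured solubility of compound 1, 33700 nM, and of compound 4, 9100 nM, a 3.7-fold lower number (0.57 log units; beyond the scatter) In the physicochemical assay compound 1 gives 33700 nM, and compound 4 gives 9100 nM.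

Within the data shown here, with only this one exchange at the position, it stays open whether the loss follows the aromatic ring or simply the larger group. A cyclohexylmethyl group on the same saturated chain carbon, which carries a ring that is not aromatic, would help separate those two readings, and a benzyl group bearing an amine would show whether the lower solubility can be recovered at this position.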